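Trifluoromethyl to Hydroxy: Predicting Compound 4

The source may hold more compounds than are shown below. What is called first, only, known or untested is meant among the compounds shown, and "the series" means these compounds.

Compound 1 `COc1cc(NC(C)CCCNC(=O)NNC(=O)Nc2cccc(F)c2)c2ncccc2c1`: in a functional assay on HeLa cells (Homo sapiens) for inhibition, read by MTT assay, with a stated time of 72 h (a higher number here means a weaker inhibitor, a lower number a stronger inhibitor), compound 1 gives only the assay limit > 250000 nM.
Compound 2 `COc1cc(NC(C)CCCNC(=O)Nc2ccc(F)cc2)c2ncccc2c1`: compound 2 gives 20000 nM.
Compound 3 `COc1cc(NC(C)CCCNC(=O)Nc2ccc(C(F)(F)F)cc2)c2ncccc2c1`: compound 3 gives 8300 nM.

Three compounds share one core and differ only in the group on the amide-type nitrogen. Compound 1 sits at a limit (the limit of > 250000 nM in this assay, at which 1 of the 3 values shown sits), so it yields no number. Among the two real numbers, compound 3 has the lowest, with compound 2 a 2.4-fold lower number from compound 2 to compound 3 (0.38 log units; beyond the scatter). The unmeasured compound 4 `COc1cc(NC(C)CCCNC(=O)Nc2ccc(O)cc2)c2ncccc2c1` differs from compound 3 as follows: hydroxy in place of trifluoromethyl on an aromatic carbon.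

The step that bears most directly on this change is the one from fluoro to trifluoromethyl, which was a 2.4-fold lower number from compound 2 to compound 3 (0.38 log units; beyond the scatter); the larger, fluorinated group gave the stronger inhibitor. Hydroxy goes the other way, being smaller and carrying a hydrogen-bond donor and acceptor where trifluoromethyl carried none. Compound 4 is therefore expected to be a weaker inhibitor than compound 3, with a 3.0-fold higher number from compound 3 to compound 4 (0.48 log units; beyond the scatter). The estimate for compound 4 is 25000 nM, in the range 8000 nM to 80000 nM.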

Compound 4, half-maximal inhibitory concentration: 70000 nM
Beside the measured number, compound 4's estimate is 2.8-fold (0.45 log units) below it; the measured number falls inside the stated range.
By their numbers in this assay, from the lowest: compound 3; then compound 2; then compound 4. At a limit, above all of these: compound 1.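

In this assay, hydroxy on this aromatic carbon, para to a large group, ranks behind both earlier groups at this place, with an 8.4-fold higher number from compound 3 to compound 4 (0.93 log units; beyond the scatter) and a 3.5-fold higher number from compound 2 to compound 4 (0.54 log units; beyond the scatter), so the change from fluoro to trifluoromethyl had shown only part of the spread that this position allows. Compound 1 gives only a limit of the assay, not a number: the limit of > 250000 nM in this assay, at which 1 of the 4 values shown sits. Even so, an at least 3.5-fold lower number from compound 1 to compound 4 (0.55 log units; beyond the scatter) shows that the hydroxy compound keeps measurable activity.

On these data alone, what stays open is whether the higher number of compound 4 goes with the hydrogen-bond donor and acceptor that enter or with the fewer heavy atoms, since this single change brings both together. A methoxy group or an amine on the same carbon would give comparisons that could help pull these apart.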